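The source may report more compounds than this note shows. Statements on the series, on what has been measured and on what is new or still open speak of the compounds shown alone.

For the measured compounds named here, compound 2, `N#CC1=C(N)Oc2c(N)cc3nc4ccccc4nc3c2C12C(=O)N(Cc1cnnn1-c1ccc(F)c(Cl)c1)c1ccccc12`, gives 43400 nM in a functional assay on A549 cells (Homo sapiens) for antiproliferative activity, read by MTT assay, with a stated time of 48 h (a lower number here means a stronger inhibitor, a higher number a weaker inhibitor), and it is the only compound in this set with a number in this assay. Compound 1, `CCOc1ccc(-n2nncc2CN2C(=O)C3(C(C#N)=C(N)Oc4c(N)cc5nc6ccccc6nc5c43)c3ccccc32)cc1`, gives only a limit in this assay, > 50000 nM. Going by the values given here, the single measured step, an at least 1.1-fold lower number from compound 1 to compound 2 (0.06 log units; that floor lies within the scatter), changes the aryl group on the aromatic nitrogen and lies within the scatter, one end of it being (the limit of > 50000 nM in this assay, at which 1 of the 2 values shown sits). Compound 3, `Cc1cc(C)c(-n2nncc2CN2C(=O)C3(C(C#N)=C(N)Oc4c(N)cc5nc6ccccc6nc5c43)c3ccccc32)c(C)c1`, differs from compound 2 by 2,4,6-trimethylphenyl in place of 3-chloro-4-fluorophenyl on an aromatic nitrogen. This exchange sits at the same aromatic nitrogen as the measured step, which moved the number by no more than the scatter, so no step beyond the scatter is expected for this assay, and a limit is about as likely as a number. Compound 3 is therefore expected to give 55000 nM in this assay, between 25000 nM and 120000 nM. This estimate means a 1.3-fold higher number from compound 2 to compound 3 (0.10 log units; within the scatter), expected to stay within the scatter.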

Compound 3, half-maximal inhibitory concentration: 12700 nM
For compound 3 the middle estimate is 4.3-fold (0.64 log units) above the measured one; the whole stated range lies above it.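

At this aromatic nitrogen, the aryl group can move the number beyond the scatter in this assay, which the earlier step did not show: 2,4,6-trimethylphenyl in place of 3-chloro-4-fluorophenyl gives a 3.4-fold lower number from compound 2 to compound 3 (0.53 log units; beyond the scatter). The same group in place of 4-ethoxyphenyl gives an at least 3.9-fold lower number from compound 1 to compound 3 (0.59 log units; beyond the scatter). That second step is only a floor, because compound 1 carries a limit and not a number: the limit of > 50000 nM in this assay, at which 1 of the 3 values shown sits.

The exchange from compound 2 to compound 3 removes both halogens and adds three methyl groups at once, so the compounds shown do not separate these changes. From the compounds shown here alone, how this assay responds to an unsubstituted phenyl, a single methyl group, or an aryl ring bearing an amine or a carboxylic acid remains open.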